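A Swap Measured Once and Expected a Second Time

A few compounds are considered here, and "the series" means these few. Any claim that something is new, unique, unknown or untested is made for them only; others in the source may bear on it.

Three compounds that share one core were tested in a functional assay on the whole organism (strain albino) for inhibition, with Rattus norvegicus as the target, read by paw edema, with stated times of 30 min and 3 h, at a dose of 0.28 mmol/kg by the oral route; a lower number here means less inhibition, a higher number more inhibition at the dose given (going by the name of the read-out). Compound 2 `CCn1c(SCC(=O)Nc2ccc(C(C)=O)cc2)nnc1-c1ccc(OC)c(OC)c1` gives 62%. Compound 1 `CCn1c(SCC(=O)Nc2ccc(/C(C)=N/O)cc2)nnc1-c1ccc(OC)c(OC)c1` differs from it in a single place: a group of 4 heavy atoms (2 carbon, 1 nitrogen, 1 oxygen; no ring) in place of a group of 3 heavy atoms (2 carbon, 1 oxygen; no ring), on an aromatic carbon. In this assay compound 1 gives 66%, which makes the step of a number 4 percentage points higher from compound 2 to compound 1 (within the scatter). Compound 3 `C=CCn1c(SCC(=O)Nc2ccc(C(C)=O)cc2)nnc1-c1ccc(OC)c(OC)c1` carries the other core, and the difference between the two cores is vinyl in place of methyl on a saturated chain carbon bound to an aromatic nitrogen. In this assay compound 3 gives 58%, a step of a number 4 percentage points lower from compound 2 to compound 3 (within the scatter). All three numbers therefore sit within the usual scatter of one another, and none of the three compounds can be called stronger or weaker than another on this evidence.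

Compound 4 `C=CCn1c(SCC(=O)Nc2ccc(/C(C)=N/O)cc2)nnc1-c1ccc(OC)c(OC)c1` has not been measured. It stands to compound 3 exactly as compound 1 stands to compound 2: a group of 4 heavy atoms (2 carbon, 1 nitrogen, 1 oxygen; no ring) in place of a group of 3 heavy atoms (2 carbon, 1 oxygen; no ring), on an aromatic carbon. The place described for this change is the same, word for word, as for the change from compound 2 to compound 1, so it is the same change made on the other core, and it occurs twice among these four compounds. Among the compounds with values here, only one instance has a measured step, and that step lay within the scatter. A step of about a number 4 percentage points higher from compound 3 to compound 4 (within the scatter) is therefore expected in this assay. Within the data shown here, the estimate for compound 4 is 62%, with a range from 50% to 74%, and it rests on the single measured step of a number 4 percentage points higher from compound 2 to compound 1 (within the scatter) together with the value of compound 3, 58%.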

Compound 4, a percentage reported as inhibition, in the whole organism at one dose (the size of the read-out at that dose, not a potency): 70%
Beside the measured number, compound 4's estimate is 8 percentage points below it, and the stated range covers the measured number.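

In this assay, replacing acetyl with the group of 4 heavy atoms on the core of compound 3 gives a step of a number 12 percentage points higher from compound 3 to compound 4 (beyond the scatter), while putting vinyl in place of methyl with that group already present gives a step of a number 4 percentage points higher from compound 1 to compound 4 (within the scatter). Only the first of these steps lies beyond the scatter, yet the acetyl swap cannot be said to behave differently on the two cores, and so, as far as these four compounds can tell, it carries over from one core to the other: the same change on two cores in this assay, a number 4 percentage points higher (within the scatter) from compound 2 to compound 1 and a number 12 percentage points higher (beyond the scatter) from compound 3 to compound 4, 8 percentage points apart, within the scatter of two such steps This does not prove that the swap has the same effect on both cores, since each core offers only one step and only one of those steps lies beyond the scatter, and the vinyl-for-methyl change likewise shows no measurable dependence on which group sits on the aromatic ring: the same change on two cores in this assay, a number 4 percentage points lower (within the scatter) from compound 2 to compound 3 and a number 4 percentage points higher (within the scatter) from compound 1 to compound 4, 8 percentage points apart, within the scatter of two such steps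

The compounds shown leave open whether the pattern would hold with an amine or a carboxylic acid in place of acetyl, or with a longer chain in place of the vinyl. On these data alone, each number is also a reading at a single dose, so how the compounds compare across a range of doses remains open.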